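Aminothiophene series: aryl replacement at the thiophene carbon

The compounds below may be only part of what the source reports. "The series", "measured", "known", "first", "only" and "open" are said of these compounds alone.

Measured compounds:
compound 1, `Cc1ccc(-c2sc(N)c(C(=O)c3ccc(Cl)cc3)c2CC(C)(C)C)cc1`, 1%
compound 2, `CC(C)c1ccc(-c2sc(N)c(C(=O)c3ccc(Cl)cc3)c2CC(C)(C)C)cc1`, 1%

In an assay on CHO cells for displacement of a labelled ligand from adenosine receptor A3 (Homo sapiens), read by scintillation counting, tested at 10 uM (a lower number here means less inhibition, a higher number more inhibition at the concentration tested (going by the name of the read-out)), compound 1 gives 1% and compound 2 gives 1%. Among the measured compounds shown here, the one measured step, no change at the digits printed from compound 1 to compound 2 (within the scatter), shows that exchanging the para substituent on the pendant phenyl leaves the read-out flat. Compound 2 therefore stands level with compound 1 at the digits printed, with no change between them beyond the scatter.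

Compound 3, `CC(C)(C)Cc1c(-c2ccco2)sc(N)c1C(=O)c1ccc(Cl)cc1`, is not yet measured in this assay. It differs from compound 2 in one place: furan-2-yl in place of 4-isopropylphenyl on an aromatic carbon. For the measured compounds named here, no measured step covers an exchange of the whole aryl group for a five-membered aromatic ring with one oxygen, so the step of no change at the digits printed from compound 1 to compound 2 (within the scatter) is the only guide, and it was within the scatter. With both measured compounds showing no inhibition at the concentration tested, the expectation for compound 3 is a step of about a number 4 percentage points higher from compound 2 to compound 3 (within the scatter) in this assay, that is, no change beyond the scatter. The estimated value for compound 3 in this assay is 5%, expected to fall between 0% and 25%.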

Compound 3, a percentage reported as inhibition, at one concentration (the size of the read-out at that concentration, not a potency): 1%
Compound 3: the middle estimate sits 4 percentage points above what was measured; the measured number falls inside the stated range.
By their numbers in this assay, from the lowest: compounds 1, 2 and 3 (each within the scatter of the next).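

In this assay, furan-2-yl in place of 4-isopropylphenyl gives no change at the digits printed from compound 2 to compound 3 (within the scatter), and furan-2-yl in place of 4-methylphenyl gives no change at the digits printed from compound 1 to compound 3 (within the scatter). The earlier pair changed only the alkyl group on a six-membered aromatic ring, whereas this change replaces the ring itself on the aromatic carbon next to the ring sulfur, bringing in a five-membered aromatic ring with one oxygen and a hydrogen-bond acceptor, and the read-out for compound 3 stays at 1%. So at this position neither the change of ring nor the added acceptor separates these compounds, although a read-out this close to nothing shows only that all three sit at the same low level, and no other measurement bears on why.

Still open, from the compounds shown here alone, is whether a ring carrying a carboxylic acid or an aminomethyl group at this carbon would move the read-out from this level. Also open, going by these compounds, is whether the same flat result would hold with a shorter chain, such as ethyl, in place of the neopentyl group, or with another group in place of the (4-chlorophenyl)carbonyl group.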